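The source may report more compounds than this note shows. Statements on the series, on what has been measured and on what is new or still open speak of the compounds shown alone.

Of the compounds shown here, three that share one core have been measured in an ADME assay on the whole organism (Rattus norvegicus, strain Sprague-Dawley) for pharmacokinetics, read by LC-MS, with a stated time of 30 min; a lower number here means that more of the compound stays in the plasma, a higher number that more of the compound sits outside the plasma. Compound 1 `N#Cc1ccc(O[C@H]2CN(S(=O)(=O)c3ccc(Cl)cc3Cl)C[C@@]2(O)CO)cc1F` gives 3.2 L/kg, the lowest of the three numbers. Compound 2 `N#Cc1ccc(O[C@H]2CN(S(=O)(=O)c3ccc(Cl)cc3Cl)C[C@@]2(O)CN)cc1F` gives 7.7 L/kg, and compound 3 `N#Cc1ccc(O[C@H]2CN(S(=O)(=O)c3ccc(Cl)cc3Cl)C[C@]2(O)CO)cc1F` gives 13 L/kg. Compound 2 carries amino in place of hydroxy on a saturated chain carbon, and this exchange comes with a 2.4-fold higher number from compound 1 to compound 2 (0.38 log units; beyond the scatter). The larger move, a 4.1-fold higher number from compound 1 to compound 3 (0.61 log units; beyond the scatter), goes with the fact that compounds 1 and 3 differ only in the configuration as drawn.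

The next compound, compound 4 `N#Cc1ccc(O[C@H]2CN(S(=O)(=O)c3ccc(Cl)cn3)C[C@@]2(O)CO)cc1F`, has not yet been measured in this assay. It departs from compound 1 at a different place: 5-chloropyridin-2-yl in place of 2,4-dichlorophenyl on a sulfonyl sulfur. In words, 5-chloropyridin-2-yl stands in place of 2,4-dichlorophenyl on a sulfonyl sulfur. Neither measured step touches that sulfonyl substituent, so both bear on the new change only indirectly. They show what modest changes elsewhere on the core can do, but they give neither a size nor a direction for this exchange. Starting from compound 1 at 3.2 L/kg, no move beyond the scatter is therefore expected, and the expected step is a 1.2-fold lower number from compound 1 to compound 4 (0.07 log units; within the scatter). For compound 4 the estimated value is 2.7 L/kg, with an expected range from 1.2 L/kg to 6 L/kg.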

Compound 4, volume of distribution at steady state: 2.2 L/kg
The estimate for compound 4 lay 1.2-fold (0.09 log units) above the measured number, within the range that was stated.
By their numbers in this assay, from the lowest: compounds 4 and 1 (each within the scatter of the next); then compounds 2 and 3 (each within the scatter of the next).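

In this assay, for the compounds shown here, the exchange on a sulfonyl sulfur gives the first measured step at this place: a 1.5-fold lower number from compound 1 to compound 4 (0.16 log units; within the scatter). Compound 4 thus carries 5-chloropyridin-2-yl, with its ring nitrogen and hydrogen-bond acceptor, in place of the 2,4-dichlorophenyl of compound 1, and the read-out does not separate the two compounds, whereas a 2.4-fold higher number from compound 1 to compound 2 (0.38 log units; beyond the scatter) and a 4.1-fold higher number from compound 1 to compound 3 (0.61 log units; beyond the scatter) both lie beyond the scatter. Going by these compounds alone, nothing on hand explains the outcome of this exchange, as the only supporting information concerns a difference in configuration elsewhere on the shared core.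

As far as these compounds go, the result rests on a single pair, so it remains open whether 5-chloropyridin-2-yl would behave the same way on the core of compound 2 or compound 3, where the amino exchange or the other configuration is in place. From the compounds shown here alone, it also remains open how far the sulfonyl substituent can be changed before the read-out moves beyond the scatter, for instance with an unsubstituted phenyl, a methyl or a cyclopropyl on the sulfonyl sulfur.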